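The compounds below may be only part of what the source reports. "The series", "measured", "known", "first", "only" and "open" are said of these compounds alone.

Compound 1 `CN1CCN(C(=O)/C=C/c2coc3ccccc3c2=O)CC1` carries a 4-methylpiperazin-1-yl amide on the chain attached to the shared core. Within the data shown here, in a functional assay on the whole organism for inhibition, with Rattus norvegicus as the target, with a stated time of 30 min, at a dose of 1 mg/kg by the intravenous route (a higher number here means more inhibition at the dose given (going by the name of the read-out), a lower number less inhibition), compound 1 gives 0%, the lowest of the two numbers measured so far. Among the measured compounds shown here, the only other measured compound, compound 2 `CNc1c(C(=O)Nc2nnn[nH]2)oc2ccccc2c1=O`, places a (1H-tetrazol-5-yl)amino amide directly on the core and carries a methylamino group besides; in this assay compound 2 gives 100%, far above compound 1 and well beyond the scatter. For the measured compounds named here, compound 2 and compound 1 differ in more than one place, so no single step links the two values.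

Compound 3 `O=C(/C=C/c1coc2ccccc2c1=O)Nc1nnn[nH]1` has not been measured. It differs from compound 1 by (1H-tetrazol-5-yl)amino in place of 4-methylpiperazin-1-yl on a carbonyl carbon. Going by the values given here, the group that enters is the same amide substituent that compound 2 carries, and compound 2 gives 100% in this assay; the chain linking the amide to the core, however, is kept from compound 1, and no measured pair shows what that linker does on its own.

An upward step from compound 1 to compound 3, beyond the scatter, is expected: a number 60 percentage points higher from compound 1 to compound 3 (beyond the scatter). For compound 3 in this assay the estimate is 60%, with a range from 20% to 95%.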

Compound 3, a percentage reported as inhibition, in the whole organism at one dose (the size of the read-out at that dose, not a potency): 65%
For compound 3 the middle estimate is 5 percentage points below the measured one, within the range that was stated.
By their numbers in this assay, from the lowest: compound 1; then compound 3; then compound 2.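

In this assay, (1H-tetrazol-5-yl)amino in place of 4-methylpiperazin-1-yl, on a carbonyl carbon whose other neighbour is a double-bonded chain carbon, gives a number 65 percentage points higher from compound 1 to compound 3 (beyond the scatter). Among these compounds, this is the first single-place step, and it shows that the read-out at this position depends strongly on the amide substituent, even with the chain of compound 1 kept. The step also appears without the methylamino group of compound 2, so that group is not required for a large read-out at this dose, although nothing measured here explains the size of the step.

Compound 2 and compound 3 differ in more than one place, so the separate contributions of the chain and the methylamino group remain unresolved; a methylamino group added to the core of compound 3, or the same amide on a saturated two-carbon chain, would separate them. As far as these compounds go, it is also open whether the effect belongs specifically to (1H-tetrazol-5-yl)amino or extends to other groups at this carbonyl carbon, such as a simple anilino amide or a carboxylic acid in place of the amide.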